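Replacing the dinitrophenyl ether in a thiophene sulfonamide urea series

This account rests on a few compounds, and the source may have more. Where it says the series, first, only, none or still open, it means among the compounds named here.

Of the compounds shown here, three have been measured in a functional assay on HL-60 cells (Homo sapiens) for inhibition, read by CCK-8 assay, with a stated time of 48 h; on this read-out higher numbers stand for weaker inhibition and lower numbers for stronger inhibition. Compound 1, `COc1ccc(Oc2ccc(C(C)C)cc2-c2ccsc2S(=O)(=O)NCCNC(=O)Nc2cc(Cl)cc(Cl)c2)cc1OC`, gives 6500 nM. Compound 2, `O=C(NCCNS(=O)(=O)c1ccc(-c2ccccc2Oc2ccc([N+](=O)[O-])c([N+](=O)[O-])c2)s1)Nc1cc(Cl)cc(Cl)c1`, gives 2300 nM. Compound 3, `O=C(NCCNS(=O)(=O)c1ccc(-c2ccccc2Oc2ccc([N+](=O)[O-])c([N+](=O)[O-])c2)s1)Nc1cc(C(F)(F)F)cc(C(F)(F)F)c1`, gives 1900 nM, the lowest of the three numbers; its gap to compound 2 lies within the scatter of repeated measurements, so the two cannot be told apart, whereas its gap to compound 1 lies beyond the scatter.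

Compound 4, `O=C(NCCNS(=O)(=O)c1ccc(-c2ccccc2O[C@H]2CC[C@@H](O)CC2)s1)Nc1cc(C(F)(F)F)cc(C(F)(F)F)c1`, has not yet been measured. It differs from compound 3 in one place: 4-hydroxycyclohexyl in place of 3,4-dinitrophenyl on an oxygen on an aromatic ring. Among the measured compounds shown here, no step between two measured compounds mirrors this exchange, so there is no measured precedent for its size or direction; the three measured values show only that the series so far spans a modest range in this assay.

With nothing to anchor the change, compound 4 is expected to give roughly 3000 nM, within a range of 1000 nM to 10000 nM. That estimate means a step of a 1.6-fold higher number from compound 3 to compound 4 (0.20 log units; within the scatter), a slight weakening that may well prove to lie within the scatter when compound 4 is tested.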

Compound 4, half-maximal inhibitory concentration: 3100 nM
For compound 4 the middle estimate is 1.0-fold (0.01 log units) below the measured one, and the stated range covers the measured number.
By their numbers in this assay, from the lowest: compounds 3, 2 and 4 (each within the scatter of the next); then compound 1.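

In this assay, putting 4-hydroxycyclohexyl in place of 3,4-dinitrophenyl on an oxygen on an aromatic ring gives a 1.6-fold higher number from compound 3 to compound 4 (0.21 log units; within the scatter) and so leaves the two compounds indistinguishable. Among the compounds shown here, this is the first reading at this position, and it shows that the six-membered aromatic ring and both nitro groups can be exchanged for a non-aromatic ring bearing a hydroxyl group without a change that rises above the scatter. Nothing available explains why the number holds across so large a change in structure.

The compounds shown leave open which part of the 4-hydroxycyclohexyl group matters, since a plain cyclohexyl ring, an amine or a carboxylic acid in place of the hydroxyl, and the other stereoisomer of the same ring do not appear among them. They also leave open whether the same exchange would read alike on compound 2, which carries a different group on the urea, and whether any group at this oxygen could move the number beyond the scatter.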